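The compounds below may be only part of what the source reports. "The series", "measured", "known", "first", "only" and "open" are said of these compounds alone.

Among the compounds with values here, in a functional assay on A549 cells (Homo sapiens) for antiproliferative activity, read by MTT assay, with a stated time of 72 h (a higher number here means a weaker inhibitor, a lower number a stronger inhibitor), compound 3 (`COc1cc(-n2cnc3ccc(-c4cccc(C)c4)cc32)cc(OC)c1OC`) gives 3820 nM, the middle of the three numbers measured so far. Compound 1 (`CCOc1ccc(-c2ccc3ncn(-c4cc(OC)c(OC)c(OC)c4)c3c2)cc1`) gives 8550 nM, the nearest value to it, and compound 2 (`COc1cc(-n2cnc3ccc(-c4cccc(O)c4)cc32)cc(OC)c1OC`) gives 250 nM, the furthest. Compound 4 (`COc1cc(-n2cnc3ccc(-c4cccc(C)c4C)cc32)cc(OC)c1OC`) differs from compound 3 by methyl in place of hydrogen on an aromatic carbon, which turns 3-methylphenyl into 2,3-dimethylphenyl: methyl in place of hydrogen on an aromatic carbon.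

Within the data shown here, no measured step makes this same change, so the evidence is indirect. The closest is the large step of a 15-fold higher number from compound 2 to compound 3 (1.18 log units; beyond the scatter), with methyl in place of hydroxy. The modest step of a 2.2-fold lower number from compound 1 to compound 3 (0.35 log units; beyond the scatter) and the large step of a 34-fold lower number from compound 1 to compound 2 (1.53 log units; beyond the scatter) both exchange the whole substituted phenyl group. These three compounds show that this part of the structure can shift the number considerably, but the large steps both involve losing or gaining the hydroxy group of compound 2, and compound 4 has none. Compound 3 at 3820 nM is therefore the best anchor, and no step beyond the scatter is expected in this assay, though a move either way remains possible. The expected step is a 1.0-fold higher number from compound 3 to compound 4 (0.02 log units; within the scatter). Compound 4 is estimated at 4000 nM, with an expected range from 1300 nM to 12000 nM.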

Compound 4, half-maximal inhibitory concentration: 9250 nM
For compound 4 the middle estimate is 2.3-fold (0.36 log units) below the measured one; low and high end bracket the measured number.
By their numbers in this assay, from the lowest: compound 2; then compound 3; then compounds 1 and 4 (each within the scatter of the next).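

In this assay, methyl in place of hydrogen on an aromatic carbon, ortho to a large group and ortho to a methyl group, gives a 2.4-fold higher number from compound 3 to compound 4 (0.38 log units; beyond the scatter); this modest step beyond the scatter shows that one added carbon at this place is enough to shift the number, which the earlier exchanges of whole substituted phenyl groups or of hydroxy for methyl could not show. The 2,3-dimethylphenyl group also brings compound 4 level with the 4-ethoxyphenyl compound, with a 1.1-fold higher number from compound 1 to compound 4 (0.03 log units; within the scatter) lying within the scatter, while a 37-fold higher number from compound 2 to compound 4 (1.57 log units; beyond the scatter) is a large step, so among the compounds shown, compound 2 with its 3-hydroxyphenyl group remains apart from the other three. Nothing measured here bears on why the added methyl shifts the number.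

The compounds shown leave open whether the same added methyl would shift the number when it stands on the 3-hydroxyphenyl group of compound 2. They also leave open whether an amine or a carboxylic acid in place of that hydroxy would keep the low number of compound 2, and whether chlorine or a longer chain on the newly substituted carbon would act as methyl does.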